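Cytotoxicity notes on the shared core series

The source may report more compounds than this note shows. Statements on the series, on what has been measured and on what is new or still open speak of the compounds shown alone.

In a toxicity assay on MT2 cells (Homo sapiens) for cytotoxicity, read by XTT assay, with a stated time of 4 days (a higher number here means that more compound is tolerated, a lower number that less compound is tolerated), compound 1 `Cc1nc(C)c([C@H](OC(C)(C)C)C(=O)O)c(N2CCC(C)(C)CC2)c1-c1ccc(Cc2ccccc2)cc1` gives >= 20000 nM, a limit of the assay.
In this assay compound 2 `Cc1nc(C)c([C@H](OC(C)(C)C)C(=O)O)c(N2CCC(C)(C)CC2)c1-c1ccc(OCCc2ccc(C#N)cc2)cc1` gives >= 33500 nM, also a limit of the assay.

Within the data shown here, compound 2 stands at a limit in this assay, and the one further value shown is a limit as well, so compound 2 cannot be ranked against it. The step that the two limits leave unreadable from compound 1 to compound 2 is therefore not readable; both ends sit at limits, as recorded in the limit of >= 20000 nM in this assay, at which 1 of the 2 values shown sits, and (the limit of >= 33500 nM in this assay, at which 1 of the 2 values shown sits).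

Compound 3 `Cc1nc(C)c([C@H](OC(C)(C)C)C(=O)O)c(N2CCC(C)(C)CC2)c1-c1ccc(OCCc2cc(F)ccc2F)cc1`, not yet measured, differs from compound 2 by 2,5-difluorophenyl in place of 4-cyanophenyl on a saturated chain carbon, two bonds along the chain from an oxygen on an aromatic ring. Among the measured compounds shown here, no measured step bears on this change, and the only step recorded in this assay is unreadable. Compound 3 is therefore expected to show no step beyond the scatter, a number no higher from compound 2 to compound 3 (the limit leaves the size open), and most likely to return a limit again. The estimate for compound 3 in this assay is 33500 nM, with a range from 15000 nM to 80000 nM.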

Compound 3, half-maximal cytotoxic concentration: >= 33500 nM
Compound 3: no number, only a limit; the forecaster's own chance of this, stated with the estimate: 80%; the middle value lies on the limit itself.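

Compound 1, compound 2 and compound 3 all stand at limits in this assay, so no step among them can be read: the limit of >= 33500 nM in this assay, at which 2 of the 3 values shown sit.

The compounds shown leave open where cytotoxicity would begin for any of the three, and whether benzyl, 2-(4-cyanophenyl)ethoxy and 2-(2,5-difluorophenyl)ethoxy differ at all in this assay.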